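This account rests on a few compounds, and the source may have more. Where it says the series, first, only, none or still open, it means among the compounds named here.

Compound 1 `CCOC(=O)C1=Cc2ccccc2OC1(OCc1cn(CC(=O)Nc2cccc(Cl)c2)nn1)C(F)(F)F` is one of three analogues built on a shared core. In a functional assay on DU-145 cells (Homo sapiens) for inhibition, read by MTT assay, with a stated time of 24 h (on this read-out higher numbers stand for weaker inhibition and lower numbers for stronger inhibition), compound 1 gives 10100 nM, the lowest of the two numbers in the set. Compound 3 `CCOC(=O)C1=Cc2ccccc2OC1(OCc1cc(-c2ccc3ccccc3c2)no1)C(F)(F)F` gives 71800 nM in this assay. Compound 2 `CCOC(=O)C1=Cc2ccccc2OC1(OCc1cc(-c2ccc(C)cc2)no1)C(F)(F)F` reaches only a limit of the assay, > 150000 nM, in this assay. Among the measured compounds shown here, the single measured step, an at least 2.0-fold lower number from compound 2 to compound 3 (0.31 log units; beyond the scatter), concerns an aromatic substituent elsewhere in the molecule and does not bear directly on the change considered here. Compound 4 `CCOC(=O)C1=Cc2ccccc2OC1(OCc1cn(CC(=O)Nc2ccc(OC)cc2)nn1)C(F)(F)F` differs from compound 1 by 4-methoxyphenyl in place of 3-chlorophenyl on an amide-type nitrogen. For the measured compounds named here, with no measured step on this change, only a modest shift in this assay is expected, in no settled direction. Compound 4 is therefore estimated at 18000 nM, between 5000 nM and 80000 nM, meaning an expected step of a 1.8-fold higher number from compound 1 to compound 4 (0.25 log units; within the scatter).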

Compound 4, half-maximal inhibitory concentration: 32700 nM
Estimate against measurement, compound 4: 1.8-fold (0.26 log units) below; the measured number falls inside the stated range.
By their numbers in this assay, from the lowest: compound 1; then compound 4; then compound 3. At a limit, above all of these: compound 2.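

In this assay, the aryl group on the amide-type nitrogen proves able to move the read-out: 4-methoxyphenyl in place of 3-chlorophenyl gives a 3.2-fold higher number from compound 1 to compound 4 (0.51 log units; beyond the scatter). Among the compounds shown here, the earlier compounds held no step at this position, so this is the first direction seen there, and it rests on this single pair. Nothing shown accounts for the step. Going by these compounds, whether the loss of chlorine or the arrival of methoxy carries it remains open. So does the outcome with a plain phenyl, a 4-chlorophenyl or an aminoalkyl chain on this nitrogen.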